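Hydroxyl position shift on the pyridin-2-yl analogue

The compounds below may be only part of what the source reports. "The series", "measured", "known", "first", "only" and "open" are said of these compounds alone.

Compound 3 `Oc1ccc(-c2cc(-c3ccccn3)cc(-c3cccc(O)c3)n2)cc1` stands only at a limit in a functional assay on HCT-15 cells (Homo sapiens) for cytotoxicity, read by CCK-8 assay; a lower number here means a stronger inhibitor, a higher number a weaker inhibitor: compound 3 gives > 50000 nM, a limit of the assay and not a number. Compound 1 `Oc1ccc(-c2cc(-c3cccs3)cc(-c3ccc(O)cc3)n2)cc1` likewise sits at a limit, compound 1 giving > 50000 nM in this assay. Going by the values given here, compound 2 `Oc1ccc(-c2cc(-c3ccsc3)cc(-c3ccc(O)cc3)n2)cc1` is the one numbered member of the series, compound 2 giving 1040 nM in this assay. Among the compounds with values here, the one measured step, an at least 48-fold lower number from compound 1 to compound 2 (1.68 log units; beyond the scatter), concerns the thiophen-2-yl to thiophen-3-yl exchange and not the hydroxyphenyl group; the limit of > 50000 nM in this assay, at which 2 of the 3 values shown sit, marks where the other two values sit. Compound 4 `Oc1ccc(-c2cc(-c3ccccn3)cc(-c3ccc(O)cc3)n2)cc1` differs from compound 3 by 4-hydroxyphenyl in place of 3-hydroxyphenyl on an aromatic carbon. Within the data shown here, no measured step touches this change, so its size cannot be read from the series; the only measured change altered a different group. The expectation is that compound 4 stays near the limit, with a number no higher from compound 3 to compound 4 (the limit leaves the size open) estimated as no step beyond the scatter. Compound 4 is therefore estimated at 50000 nM in this assay, within 8000 nM to 200000 nM.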

Compound 4, half-maximal inhibitory concentration: > 50000 nM
Compound 4: only a limit was reported; the forecaster's own chance of this, stated with the estimate: 70%; the middle value lies on the limit itself.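

In this assay compound 4 gives > 50000 nM, a limit of the assay and not a number. The 3-hydroxyphenyl to 4-hydroxyphenyl exchange therefore leaves the pyridin-2-yl analogue without a readable number, and the steps between compound 3 and compound 4 and between compound 1 and compound 4 cannot be read, since both ends of each are limits. With the two 4-hydroxyphenyl groups held constant, pyridin-2-yl in place of thiophen-3-yl gives an at least 48-fold higher number from compound 2 to compound 4 (1.68 log units; beyond the scatter), so compound 2 remains the only compound with a number: the limit of > 50000 nM in this assay, at which 3 of the 4 values shown sit.

Open, going by these compounds, is whether the hydroxyl position changes the number at all on a background that gives a readable value, such as the thiophen-3-yl group of compound 2. Also open, on these data alone, is how a methoxy group or an amine in place of the hydroxyl would read, or a pyridin-3-yl group in place of pyridin-2-yl.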